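From a Fluoro to a Trifluoromethyl Group on Compound 3

The source may hold more compounds than are shown below. What is called first, only, known or untested is meant among the compounds shown, and "the series" means these compounds.

Of the compounds shown here, three built on one shared core have been measured in a functional assay on HCT-116 cells (Homo sapiens) for antiproliferative activity, read by MTT assay, with a stated time of 72 h; on this read-out higher numbers stand for weaker inhibition and lower numbers for stronger inhibition. Compound 1 `CC(C)(C)OC(=O)Nc1ccc(NC(=O)CCc2cccc3c2B(O)OC3)cc1` gives 24000 nM. Compound 2 `COc1ccc(NC(=O)CCc2cccc3c2B(O)OC3)cc1OC` gives only a limit here, > 100000 nM. This is the limit of > 100000 nM in this assay, at which 1 of the 3 values shown sits. Compound 3 `O=C(CCc1cccc2c1B(O)OC2)Nc1cccc(-c2ccc(F)cc2)c1` gives 550 nM, the lowest of the two numbers, and compound 1 stands beyond the scatter from it.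

Compound 4 `O=C(CCc1cccc2c1B(O)OC2)Nc1cccc(-c2ccc(C(F)(F)F)cc2)c1` differs from compound 3 in one place: trifluoromethyl in place of fluoro on an aromatic carbon. Among the compounds with values here, no measured pair shows this change, so its effect cannot be read from these data. Compound 4 is expected to stay close to compound 3, with a step in this assay of no change at the digits printed from compound 3 to compound 4 (within the scatter) that lies within the scatter. Compound 4 is therefore estimated at 550 nM, between 150 nM and 2000 nM.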

Compound 4, half-maximal inhibitory concentration: 550 nM
Compound 4: the middle estimate sits on the measured number at the digits printed; the measured number falls inside the stated range.
By their numbers in this assay, from the lowest: compounds 3 and 4 (each within the scatter of the next); then compound 1. At a limit, above all of these: compound 2.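

In this assay, trifluoromethyl in place of fluoro, para to a large group, gives no change at the digits printed from compound 3 to compound 4 (within the scatter). Within the data shown here, this is the first step between measured compounds in the set, and it shows that this position can carry either group, the 4-fluorophenyl or the 4-(trifluoromethyl)phenyl, with no step beyond the scatter. No measurement shown gives a reason for this outcome. From the compounds shown here alone, whether the position holds up with an amine, a carboxylic acid or a methoxy group in place of these groups stays open, as does whether the same change reads alike elsewhere on the shared core.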